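The source may hold more compounds than are shown below. What is called first, only, known or untested is meant among the compounds shown, and "the series" means these compounds.

Measured compounds:
compound 1 `Nc1nc(Cl)c(-c2nccs2)c(N[C@@H]2C[C@H](CO)[C@@H](O)[C@H]2O)n1`
compound 2 `Nc1nc(Cl)c(-c2nc3ccccc3s2)c(N[C@@H]2C[C@H](CO)[C@@H](O)[C@H]2O)n1`
compound 3 `Nc1nc(Cl)c(-c2nc3ccc(F)cc3s2)c(N[C@@H]2C[C@H](CO)[C@@H](O)[C@H]2O)n1`

In an ADME assay on cells (Homo sapiens) for cytotoxicity, read by polymerase chain reaction, with a stated time of 3 days (a higher number here means that more compound is tolerated, a lower number that less compound is tolerated), compound 1 is reported only as the assay limit, > 25000 nM. Compound 2 gives 14000 nM. Compound 3 is likewise reported only as a limit, > 25000 nM. On the numbers shown, compound 3 thus stands with compound 1 at the limit of > 25000 nM in this assay, at which 2 of the 3 values shown sit, rather than at a measured figure. Compound 4 `Nc1nc(Cl)c(-c2nc3ccc(Cl)cc3s2)c(N[C@@H]2C[C@H](CO)[C@@H](O)[C@H]2O)n1` differs from compound 3 by chloro in place of fluoro on an aromatic carbon. Among the compounds with values here, no measured step touches this same place. The nearest steps are an at least 1.7-fold lower number from compound 1 to compound 2 (0.25 log units; that floor lies within the scatter) and an at least 1.7-fold higher number from compound 2 to compound 3 (0.25 log units; that floor lies within the scatter), both bounded by the limit and both within the scatter. A step beyond the scatter is therefore not expected in this assay. Compound 4 is estimated at 25000 nM, with a range of 10000 nM to 60000 nM, most probably again as a limit. The expected step is a number no higher from compound 3 to compound 4 (the limit leaves the size open).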

Compound 4, half-maximal cytotoxic concentration: 16000 nM
The estimate for compound 4 lay 1.6-fold (0.19 log units) above the measured number; low and high end bracket the measured number.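

In this assay, chloro on this aromatic carbon gives a measured figure where fluoro gave only a limit, which allows a floor and no more: an at least 1.5-fold lower number from compound 3 to compound 4 (0.19 log units; that floor lies within the scatter). Chloro in place of hydrogen at the same place gives a 1.1-fold higher number from compound 2 to compound 4 (0.06 log units; within the scatter), so this substitution stays within the scatter. The full size of the fluoro to chloro step stays unknown because one side of it is a limit: the limit of > 25000 nM in this assay, at which 2 of the 4 values shown sit.

The compounds shown leave open whether a methoxy group or an amine on this carbon would give a step beyond the scatter. They also leave open whether chloro on another carbon of this ring would read the same.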